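This account rests on a few compounds, and the source may have more. Where it says the series, first, only, none or still open, it means among the compounds named here.

Measured so far:

Compound 1, `CC1(C)CCC(C)(C)c2cc(/C=C/c3cccc(N)c3)ccc21`, gives 20000 nM.
Compound 3, `COc1ccc(/C=C\c2ccc3c(c2)C(C)(C)CCC3(C)C)cc1N`, gives 25000 nM.
Compound 2, `C/C(=C\c1cccc(C(=O)O)c1)c1ccc2c(c1)C(C)(C)CCC2(C)C`, gives only a limit, > 100000 nM.

These values come from a functional assay on HL-60 cells (Homo sapiens) for cytotoxicity; a lower number here means a stronger inhibitor, a higher number a weaker inhibitor. Compound 3 and compound 1 give numbers that lie within the usual scatter of each other, so neither can be called the more active of the two. For compound 2 the reading is a limit of the assay rather than a number, and one of the three values shown sits at that limit (the limit of > 100000 nM in this assay, at which 1 of the 3 values shown sits).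

Compound 4, `COc1ccc(/C=C\c2ccc3c(c2)C(C)(C)CCC3(C)C)cc1`, has not yet been tested in this assay. It differs from compound 3 in a single place: hydrogen in place of amino on an aromatic carbon. For the measured compounds named here, no pair of measured compounds differing in exactly one place is available, so there is no measured step to lean on for the size of this change. The expectation is therefore modest: a step that stays within the usual scatter, in no clear direction, is the most likely outcome, with some chance that the reading ends up as a limit.

On that basis compound 4 is expected to give about 25000 nM, estimated to lie between 8000 nM and 80000 nM. The expected step is no change at the digits printed from compound 3 to compound 4 (within the scatter).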

Compound 4, half-maximal inhibitory concentration: 50000 nM
Compound 4: the middle estimate sits 2.0-fold (0.30 log units) below what was measured; the range from low to high includes it.
By their numbers in this assay, from the lowest: compounds 1, 3 and 4 (each within the scatter of the next, the first and the last beyond it). At a limit, above all of these: compound 2.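

In this assay, for the compounds shown here, the first single-place comparison in this set is a 2.0-fold higher number from compound 3 to compound 4 (0.30 log units; within the scatter), so replacing the amino group on this aromatic carbon, ortho to a methoxy group, with hydrogen leaves the reading within what repeat measurements would give. The amino group at this position is therefore not shown to be needed for the modest activity seen, and compound 4 still gives a measured number rather than a limit. The only limit in the set belongs to compound 2: the limit of > 100000 nM in this assay, at which 1 of the 4 values shown sits.

From the compounds shown here alone, it remains open whether a hydroxyl group, a fluorine atom or an acetamide on the same aromatic carbon would move the number beyond the scatter, in either direction. Going by these compounds, compound 1 and compound 2 each differ from compound 4 in more than one place, so no single change can be read from them, and what the methoxy group contributes on its own also remains unknown.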